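Methoxy shift on the chain-terminal aryl of compound 2

This account rests on a few compounds, and the source may have more. Where it says the series, first, only, none or still open, it means among the compounds named here.

Compound 2 `COc1cccc(COc2ccc3cc(C(=O)/C=C/c4cc(OC)ccc4OC)c(=O)oc3c2)c1` carries a 2,5-dimethoxyphenyl on a double-bonded chain carbon bound to a double-bonded chain carbon. In a functional assay on MCF7 cells (Homo sapiens) for cytotoxicity, read by MTT assay, with a stated time of 72 h (on this read-out lower numbers stand for stronger inhibition and higher numbers for weaker inhibition), compound 2 reaches only the limit of > 100000 nM, which is a limit of the assay and not a number. Compound 1 `COc1cccc(COc2ccc3cc(C(=O)/C=C/c4c(Cl)cccc4Cl)c(=O)oc3c2)c1`, with a 2,6-dichlorophenyl in that place, gives 10100 nM in this assay. Going by the values given here, the single measured step, an at least 9.9-fold higher number from compound 1 to compound 2 (0.99 log units; beyond the scatter), rests on compound 2 sitting at the limit of > 100000 nM in this assay, at which 1 of the 2 values shown sits, so its size is known only as a lower bound. Compound 3 `COc1cccc(COc2ccc3cc(C(=O)/C=C/c4cccc(OC)c4OC)c(=O)oc3c2)c1` is the next member: 2,3-dimethoxyphenyl in place of 2,5-dimethoxyphenyl on a double-bonded chain carbon bound to a double-bonded chain carbon. Among the compounds with values here, no measured step compares two dimethoxyphenyl isomers, so the only guide is that compound 2 sits at the limit while compound 1, bearing a different group altogether, is itself a weak inhibitor. No change beyond the scatter is expected, a number no higher from compound 2 to compound 3 (the limit leaves the size open), and a repeat of the limit is quite possible. Compound 3 is therefore expected to give about 100000 nM in this assay, estimated between 30000 nM and 300000 nM.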

Compound 3, half-maximal inhibitory concentration: 35100 nM
Compound 3: middle estimate off by 2.8-fold (0.45 log units), on the high side, and the stated range covers the measured number.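

In this assay, the two dimethoxyphenyl isomers do not read alike on a double-bonded chain carbon bound to a double-bonded chain carbon: 2,3-dimethoxyphenyl in place of 2,5-dimethoxyphenyl gives an at least 2.8-fold lower number from compound 2 to compound 3 (0.45 log units; beyond the scatter), so rearranging the same atoms is enough to move the read-out at this position. The 2,6-dichlorophenyl still holds the lowest number of the three, with a 3.5-fold higher number from compound 1 to compound 3 (0.54 log units; beyond the scatter), and the order among the three compounds, compound 1, then compound 3, then compound 2, rests on steps all printed as beyond the scatter. Compound 2 stands at a limit of the assay and not at a number, so the step out of it is only a lower bound: the limit of > 100000 nM in this assay, at which 1 of the 3 values shown sits.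

Open, from the compounds shown here alone, is how 2,6-dimethoxyphenyl would read at this place, since it would set methoxy against chlorine in one arrangement, whereas the present comparisons with compound 1 change both the groups and their arrangement. Also open, going by these compounds, is whether one methoxy group, an unsubstituted phenyl or a dimethylamino-bearing phenyl would follow the same order in this assay.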